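Removing a Methoxy Group: Expected Permeability of Compound 4

This account rests on a few compounds, and the source may have more. Where it says the series, first, only, none or still open, it means among the compounds named here.

Of the compounds shown here, three sharing one core have been measured in an ADME assay for permeability; on this read-out lower numbers stand for lower permeability and higher numbers for higher permeability. Compound 1 `CNC(=O)c1cc(C(=O)N[C@H]2CC[C@H](O)CC2)c([C@@H](C)c2ccc(Cl)cc2)o1` gives 150 nm/s. Compound 2 `CNC(=O)c1cc(C(=O)N[C@H]2[C@@H]3COC[C@@H]32)c([C@@H](C)c2ccccc2)o1` gives 200 nm/s. Compound 3 `CNC(=O)c1cc(C(=O)N[C@H]2CC[C@H](O)CC2)c([C@@H](C)c2cccc(OC)c2)o1` gives 44 nm/s, the lowest of the three numbers, with compound 1 nearest and compound 2 furthest away, both beyond the scatter. Within the data shown here, the single measured step, a 3.4-fold lower number from compound 1 to compound 3 (0.53 log units; beyond the scatter), shows that swapping the aromatic ring on the saturated chain carbon shifts the read-out by a modest but real amount.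

Compound 4 `CNC(=O)c1cc(C(=O)N[C@H]2CC[C@H](O)CC2)c([C@@H](C)c2ccccc2)o1` differs from compound 3 by hydrogen in place of methoxy on an aromatic carbon; cut one bond further out, the same difference reads 3-methoxyphenyl to phenyl. Among the measured compounds shown here, no measured pair shows this exact change on this core. Compound 2 carries a phenyl with a different amine part and gives a number above compound 3, which is only a loose pointer. Because the step of a 3.4-fold lower number from compound 1 to compound 3 (0.53 log units; beyond the scatter) moved the number modestly when the aryl group changed, compound 4 is expected to move back upward by a similar margin. Compound 4 is therefore estimated at 120 nm/s, with a range from 60 nm/s to 250 nm/s. The expected step of a 2.7-fold higher number from compound 3 to compound 4 (0.44 log units; beyond the scatter) is modest, in the upward direction.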

Compound 4, apparent permeability: 42 nm/s
Estimate against measurement, compound 4: 2.9-fold (0.46 log units) above, outside the stated range (below it).
By their numbers in this assay, from the lowest: compounds 4 and 3 (each within the scatter of the next); then compounds 1 and 2 (each within the scatter of the next).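

In this assay, swapping methoxy for hydrogen on this aromatic carbon gives a 1.0-fold lower number from compound 3 to compound 4 (0.02 log units; within the scatter), so on this core 3-methoxyphenyl and phenyl cannot be told apart. The earlier drop from compound 1 to compound 3 therefore reads differently: it is not a sign that methoxy sets the lower number, since the plain phenyl of compound 4 sits at the same level, and the two single changes that lead to compound 4 from the higher compounds are a 3.6-fold lower number from compound 1 to compound 4 (0.55 log units; beyond the scatter), with hydrogen replacing chloro, and a 4.8-fold lower number from compound 2 to compound 4 (0.68 log units; beyond the scatter), with the amine part exchanged. Nothing available gives a reason for any of these steps.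

The compounds shown leave open whether a different group on this same aromatic carbon, such as fluoro, nitrile or an amine, would also match phenyl or would move the number. They also leave open whether methoxy and hydrogen would still read alike with the amine part of compound 2 in place, since the one pair shown here carries only the amine part of compound 3.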